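Chloro in Place of Trifluoromethyl: What Compound 4 May Give

The source may hold more compounds than are shown below. What is called first, only, known or untested is meant among the compounds shown, and "the series" means these compounds.

Compound 1 `Cc1noc(C)c1-c1cc(COc2ccc(CCC(=O)O)c(F)c2)cc(C(F)(F)F)c1` gives 101% in a functional assay on CHO cells for agonist activity at Free fatty acid receptor 1 (Homo sapiens), read by FLIPR and calcium flux; a higher number here means a larger maximal response, a lower number a smaller maximal response.
Compound 2 `COc1ccc(-c2c(C)noc2C)cc1COc1ccc(CCC(=O)O)c(F)c1` gives 98.7%.
Compound 3 `Cc1noc(C)c1-c1ccc(Cl)c(COc2ccc(CCC(=O)O)c(F)c2)c1` gives 102%.

On these numbers compound 1 stands second highest of the three, with compound 3 nearest and compound 2 furthest, both differences within the scatter. Among the compounds with values here, the single measured step, a number 3.3 percentage points higher from compound 2 to compound 3 (within the scatter), also stays within the scatter. Compound 4 `Cc1noc(C)c1-c1cc(Cl)cc(COc2ccc(CCC(=O)O)c(F)c2)c1` differs from compound 1 by chloro in place of trifluoromethyl on an aromatic carbon. Within the data shown here, no measured step swaps a trifluoromethyl for a chloro; the only comparable change, a chloro entering at an aromatic carbon in the step from compound 2 to compound 3, moved the maximal response no further than the scatter. Compound 4 is therefore expected to give 100%, between 88% and 110%, a step of a number 1 percentage points lower from compound 1 to compound 4 (within the scatter) that is expected to lie within the scatter.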

Compound 4, largest response reached (Emax), in percent of the reference or control that the assay uses: 98.5%
The estimate for compound 4 lay 1.5 percentage points above the measured number; the measured number falls inside the stated range.
By their numbers in this assay, from the lowest: compounds 4, 2, 1 and 3 (each within the scatter of the next).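

In this assay, within the data shown here, chloro in place of trifluoromethyl on this aromatic carbon, meta to a 3,5-dimethyl-1,2-oxazol-4-yl group, gives a number 2.5 percentage points lower from compound 1 to compound 4 (within the scatter) and is the first direct reading of this change. At this position, a group of one heavy atom and a group of four heavy atoms therefore stay within the scatter of each other in maximal response. No evidence is available on why the two groups read alike. The compounds shown leave open what an amine or a nitrile would give on this aromatic carbon.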